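The source may hold more compounds than are shown below. What is called first, only, known or untested is meant among the compounds shown, and "the series" means these compounds.

Compound 1 `C#CCOc1ccc(/C=C/C(=O)c2ccc(Br)cc2)cc1` is the reference point of the series. In a functional assay on MCF7 cells (Homo sapiens) for inhibition, read by MTT assay, with a stated time of 48 h, tested at 10 uM (a lower number here means less inhibition of growth, a higher number more inhibition of growth at the concentration tested), compound 1 gives 45%. Compound 2 `C#CCOc1ccc(/C=C/C(=O)c2ccc(OC)cc2)cc1` carries the change (methoxy in place of bromo on an aromatic carbon), and in this assay compound 2 gives 32%. That change made a step of a number 13 percentage points lower from compound 1 to compound 2 (beyond the scatter), a modest loss that lies beyond the scatter.

Compound 3 `O=C(/C=C/c1ccc(OCc2cn(Cc3ccccc3)nn2)cc1)c1ccc(Br)cc1` has a different core; the difference between the core of compound 1 and the core of compound 3 is not broken down here. In this assay compound 3 gives 34%, a number within the scatter of compound 2 and beyond the scatter below compound 1.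

Compound 4 `COc1ccc(C(=O)/C=C/c2ccc(OCc3cn(Cc4ccccc4)nn3)cc2)cc1` is not yet measured. It differs from compound 3 by methoxy in place of bromo on an aromatic carbon, the same change as from compound 1 to compound 2, at the same place on the same kind of ring. Among the measured compounds shown here, the expectation rests on the single measured instance of this change, the step of a number 13 percentage points lower from compound 1 to compound 2 (beyond the scatter), applied to the value of compound 3. Compound 4 is therefore expected to show a step of a number 12 percentage points lower from compound 3 to compound 4 (beyond the scatter) in this assay. For the measured compounds named here, for compound 4 the estimated value in this assay is 22%, with a range from 9% to 35%; the single precedent and the general scatter keep this range wide.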

Compound 4, percent growth inhibition at one concentration: 70%
Estimate against measurement, compound 4: 48 percentage points below; the whole stated range lies below it.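

Methoxy in place of bromo on an aromatic carbon, para to a large group, gives in this assay a step of a number 36 percentage points higher from compound 3 to compound 4 (beyond the scatter), so the gain sits on the core shared by compound 3 and compound 4. The size and direction of this change do not carry from one core to the other among the two pairs shown: the same change on two cores in this assay, a number 13 percentage points lower (beyond the scatter) from compound 1 to compound 2 and a number 36 percentage points higher (beyond the scatter) from compound 3 to compound 4, 49 percentage points apart, beyond the scatter of two such steps This shows that a step measured on one core is a poor guide to the same change on the other, but it does not show which part of the core difference goes with the reversal, and two pairs give no rule for a third core.

Left open is how other groups at the same place, such as a chloro, a nitrile or an amine, behave on each core. Also open, on these data alone, is whether the opposite directions persist at other concentrations, and which part of the core of compound 3 goes with the higher number.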